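Swapping a side group: cell toxicity of one pair

The source may hold more compounds than are shown below. What is called first, only, known or untested is meant among the compounds shown, and "the series" means these compounds.

compound 1, `CC(C)(C)[Si](CCc1c(OCc2c(Cl)cccc2Cl)nc2ccc(Cl)cc2c1-c1ccccc1Cl)(c1ccccc1)c1ccccc1`: > 1020000 nM
compound 2, `OCCc1c(OCc2c(Cl)cccc2Cl)nc2ccc(Cl)cc2c1-c1ccccc1Cl`: 38500 nM
compound 3, `CC(C)(C)[Si](CCc1c(N2CCCCC2)nc2ccc(Cl)cc2c1-c1ccccc1Cl)(c1ccccc1)c1ccccc1`: > 968000 nM

All three values come from an ADME assay on HepG2 2.2.15 cells (Homo sapiens) for cytotoxicity; on this read-out higher numbers stand for lower toxicity in this test and lower numbers for higher toxicity in this test. For compound 1 the value is a limit of the assay, not a number (the limit of > 1020000 nM in this assay, at which 1 of the 3 values shown sits). For compound 3 the value is likewise a limit (the limit of > 968000 nM in this assay, at which 1 of the 3 values shown sits). Compound 2 alone gives a definite number. The change from compound 1 to compound 3 is piperidin-1-yl in place of (2,6-dichlorobenzyl)oxy on an aromatic carbon, and its step is a step that the two limits leave unreadable from compound 1 to compound 3. The difference between the cores of compound 1 and compound 2 is not broken down here. Compound 4, `OCCc1c(N2CCCCC2)nc2ccc(Cl)cc2c1-c1ccccc1Cl`, is still unmeasured; it arises from compound 2 by piperidin-1-yl in place of (2,6-dichlorobenzyl)oxy on an aromatic carbon, the same kind of change, though here the place is ortho to a 2-hydroxyethyl group (3 heavy atoms) where before it was ortho to a large group. The expectation therefore rests on compound 2, whose number is 38500 nM. The step of a 1.0-fold higher number from compound 2 to compound 4 (0.02 log units; within the scatter) is expected to be small, with a wide band. Compound 4 is expected to give 40000 nM in this assay, between 10000 nM and 200000 nM.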

Compound 4, half-maximal cytotoxic concentration: 155000 nM
Compound 4: middle estimate off by 3.9-fold (0.59 log units), on the low side; measured number inside the range.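

In this assay, on the core with the 2-hydroxyethyl group, putting piperidin-1-yl in place of (2,6-dichlorobenzyl)oxy gives a 4.0-fold higher number from compound 2 to compound 4 (0.60 log units; beyond the scatter), so this one pair moves toward lower toxicity in this test. Compound 1 gives only a limit of the assay, not a number: the limit of > 1020000 nM in this assay, at which 1 of the 4 values shown sits.

Compound 3 likewise gives only a limit, so the same change on that other core cannot be read, and nothing here shows that the step carries from one core to the other: the limit of > 968000 nM in this assay, at which 1 of the 4 values shown sits.

Still open, going by these compounds, is whether the step would hold for another amine in the same place, such as morpholine or dimethylamine. Also open, on these data alone, is how a carboxylic acid in place of the 2-hydroxyethyl group would read.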